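The compounds below may be only part of what the source reports. "The series", "measured", "known", "first", "only" and "open" are said of these compounds alone.

Compounds measured in an ADME assay on HeLa cells (Homo sapiens) for cytotoxicity, read by ATP content, with a stated time of 3 days (a lower number here means that less compound is tolerated, a higher number that more compound is tolerated), so far:

Compound 1, `COc1ccc(-n2c(=O)n(Cc3cc4cc(Cl)ccc4n3CCCC#N)c3cnccc32)cc1`: a limit of this assay, > 50000 nM.
Compound 2, `N#CCCCn1c(Cn2c(=O)n(-c3ccncn3)c3ccncc32)cc2cc(Cl)ccc21`: likewise a limit, > 50000 nM.
Compound 3, `O=c1n(Cc2nc3cnccc3n2CCCCO)c2cnccc2n1C1CC1`: a limit as well, > 100000 nM.

For the measured compounds named here, no compound has yet given a number in this assay. Compound 2 stands at the limit that holds two of the three values, (the limit of > 50000 nM in this assay, at which 2 of the 3 values shown sit); the remaining value sits at a higher limit, (the limit of > 100000 nM in this assay, at which 1 of the 3 values shown sits). Nothing in these figures orders the three compounds against one another.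

The next compound, compound 4, `N#CCCCn1c(Cn2c(=O)n(-c3ccc(C(=O)O)cc3)c3ccncc32)cc2cc(Cl)ccc21`, differs from compound 2 in one place: 4-carboxyphenyl in place of pyrimidin-4-yl on an aromatic nitrogen.

Going by the values given here, only one measured step touches the same position on the aromatic nitrogen, and it is the step that the two limits leave unreadable from compound 1 to compound 2, whose size the two limits hide. No readable step exists anywhere in the series, so there is no measured basis for expecting the carboxyphenyl group to move the value in either direction beyond the scatter.

For compound 4 the expectation is therefore that this assay again reports a limit rather than a number, with an estimated value of 50000 nM and a range from 20000 nM to 100000 nM. This estimate means an expected step of a number no higher from compound 2 to compound 4 (the limit leaves the size open), that is, no change that the assay can resolve.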

Compound 4, half-maximal cytotoxic concentration: > 50000 nM
Compound 4: no number, only a limit; the forecaster's own chance of this, stated with the estimate: 85%; the middle value lies on the limit itself.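

In this assay compound 4 gives only a limit, > 50000 nM. Compound 1 and compound 2 also stand at limits, so neither step to compound 4 can be read. The compounds shown leave open how large the half-maximal cytotoxic concentration of any of them is, and whether the group on the aromatic nitrogen changes it.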